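Swapping a Chlorophenyl for Thiophene on the Amide

The compounds below may be only part of what the source reports. "The series", "measured", "known", "first", "only" and "open" are said of these compounds alone.

Three compounds share one core and differ only in the group attached to the carbonyl carbon that sits on an amide-type nitrogen in a ring. Compound 1 `CC(C)OC(=O)C1=CN(C(=O)C2CCCCC2)CC(C)(C)c2cc(C#N)[nH]c21` carries a cyclohexyl there, and in an assay on HEK293 cells for agonist activity at Bile acid receptor (Homo sapiens), read by a luciferase reporter (a higher number here means that more compound is needed for the effect, a lower number that less compound is needed), compound 1 gives 6.5 nM. Compound 2 `CC(C)OC(=O)C1=CN(C(=O)c2cccc(C(F)(F)F)c2)CC(C)(C)c2cc(C#N)[nH]c21` carries a 3-(trifluoromethyl)phenyl and gives 8.5 nM. Compound 3 `CC(C)OC(=O)C1=CN(C(=O)c2cccc(Cl)c2)CC(C)(C)c2cc(C#N)[nH]c21` carries a 3-chlorophenyl and gives 12 nM, the highest of the three numbers, yet every gap to it stays within the scatter: a 1.8-fold higher number from compound 1 to compound 3 (0.27 log units; within the scatter) and a 1.4-fold higher number from compound 2 to compound 3 (0.15 log units; within the scatter). Compound 4 `CC(C)OC(=O)C1=CN(C(=O)c2cccs2)CC(C)(C)c2cc(C#N)[nH]c21` is not yet measured. Its difference from compound 3 reads: thiophen-2-yl in place of 3-chlorophenyl on a carbonyl carbon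

The measured steps that bear on this are those that change the group on the carbonyl carbon. Replacing the cyclohexyl by an aromatic ring gave a 1.3-fold higher number from compound 1 to compound 2 (0.12 log units; within the scatter) and a 1.8-fold higher number from compound 1 to compound 3 (0.27 log units; within the scatter); exchanging one substituent on that ring for another gave a 1.4-fold higher number from compound 2 to compound 3 (0.15 log units; within the scatter). All three stayed within the scatter, so the group on this carbonyl carbon has so far barely moved the number. Within the data shown here, no measured compound carries a five-membered ring here, so the step is less certain than it would otherwise be. The expected step is a 1.2-fold lower number from compound 3 to compound 4 (0.08 log units; within the scatter), meaning no change beyond the scatter. Compound 4 is therefore estimated at 10 nM, with a range from 4 nM to 30 nM.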

Compound 4, half-maximal effective concentration: 16 nM
Compound 4: middle estimate off by 1.6-fold (0.20 log units), on the low side; measured number inside the range.
By their numbers in this assay, from the lowest: compounds 1, 2, 3 and 4 (each within the scatter of the next, the first and the last beyond it).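

The result shows that a five-membered aromatic ring with one hetero atom can take the place of a six-membered one on this carbonyl carbon without a clear shift in this assay: exchanging 3-chlorophenyl for thiophen-2-yl gives a 1.3-fold higher number from compound 3 to compound 4 (0.12 log units; within the scatter), and exchanging 3-(trifluoromethyl)phenyl for it gives a 1.9-fold higher number from compound 2 to compound 4 (0.27 log units; within the scatter). The group here is not wholly without influence, however, as exchanging cyclohexyl for thiophen-2-yl gives a 2.5-fold higher number from compound 1 to compound 4 (0.39 log units; beyond the scatter), a modest step and the first at this position to pass the scatter, while compound 2 and compound 3 stay within the scatter of both ends of it. Nothing available explains why these two groups end up apart.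

Cyclohexyl is the only saturated ring shown here and thiophen-2-yl the only five-membered one, so it remains open whether this modest step reflects those two ring types in general or only these two groups. As far as these compounds go, how this position would respond to furan-2-yl, cyclopentyl, a longer chain such as butyl, or a ring carrying an amine or a carboxylic acid also remains open.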